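The compounds below may be only part of what the source reports. "The series", "measured", "known", "first", "only" and "open" are said of these compounds alone.

Compound 1 `O=P(O)(OC[C@@]12C[C@@H]1[C@@H](n1cnc3c(O)ncnc31)[C@H](O)[C@@H]2O)OP(=O)(O)OC[C@@]12C[C@@H]1[C@@H](n1cnc3c(O)ncnc31)[C@H](O)[C@@H]2O` and compound 2 `CNC(=O)[C@@]12C[C@@H]1[C@@H](n1cnc3c(O)ncnc31)[C@H](O)[C@@H]2O` were both tested in an assay on HEK293 cells for displacement of a labelled ligand from adenosine receptor A3 (Homo sapiens); on this read-out higher numbers stand for weaker inhibition and lower numbers for stronger inhibition. Compound 1 gives 21600 nM, and compound 2 gives 28800 nM. Compound 2 thus stands at the top of these two numbers, yet its gap to compound 1 lies within the scatter, so the two cannot be told apart. Compound 3 `OC[C@@]12C[C@@H]1[C@@H](n1cnc3c(O)ncnc31)[C@H](O)[C@@H]2O` has not yet been measured in this assay. It differs from compound 2 by one change: hydroxymethyl in place of methylcarbamoyl on a saturated ring carbon. For the measured compounds named here, with no measured step to lean on, the expected step is a 1.3-fold lower number from compound 2 to compound 3 (0.12 log units; within the scatter), none beyond the scatter. Compound 3 is accordingly estimated at 22000 nM, with a range from 6000 nM to 80000 nM.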

Compound 3, inhibition constant: 30000 nM
The estimate for compound 3 lay 1.4-fold (0.13 log units) below the measured number; the measured number falls inside the stated range.
By their numbers in this assay, from the lowest: compounds 1, 2 and 3 (each within the scatter of the next).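

In this assay, replacing methylcarbamoyl with hydroxymethyl on this saturated ring carbon gives a 1.0-fold higher number from compound 2 to compound 3 (0.02 log units; within the scatter) and so the two groups cannot be told apart at this position. For the compounds shown here, this is the first step that can be read here, as compounds 1 and 2 differ in more than one place. Nothing available explains this result. Still open, on these data alone, is whether an amine, a carboxylic acid or a longer chain on this carbon would give a number beyond the scatter from that of compound 2.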